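Hydrogen for chloro on the anilide ring of compound 1

The source may report more compounds than this note shows. Statements on the series, on what has been measured and on what is new or still open speak of the compounds shown alone.

Measured so far:
compound 1, `O=C(CCCCCCNC(=O)C(O)(O)C(F)(F)F)Nc1ccc(Cl)cc1`: 4230 nM
compound 2, `COc1ccc2nc(NC(=O)CCCCCCNC(=O)C(O)(O)C(F)(F)F)sc2c1`: 7560 nM

In a functional assay on HCT-116 cells (Homo sapiens) for inhibition, read by colorimetric assay, with a stated time of 3 days (a higher number here means a weaker inhibitor, a lower number a stronger inhibitor), compound 1 gives 4230 nM, the lowest of the two numbers. Compound 2 gives 7560 nM, which lies within the scatter of compound 1. Compound 3, `O=C(CCCCCCNC(=O)C(O)(O)C(F)(F)F)Nc1ccccc1`, differs from compound 1 by hydrogen in place of chloro on an aromatic carbon. For the measured compounds named here, no measured pair isolates this change, so its effect is unknown. The step from a 1.5-fold higher number from compound 1 to compound 3 (0.19 log units; within the scatter) is expected to be a modest weakening, near the edge of the scatter. Compound 3 is expected to give 6500 nM, in the range 2500 nM to 17000 nM.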

Compound 3, half-maximal inhibitory concentration: 9140 nM
Compound 3: the middle estimate sits 1.4-fold (0.15 log units) below what was measured, and the stated range covers the measured number.
By their numbers in this assay, from the lowest: compounds 1, 2 and 3 (each within the scatter of the next, the first and the last beyond it).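

Hydrogen in place of chloro on the aromatic carbon gives a 2.2-fold higher number from compound 1 to compound 3 (0.33 log units; beyond the scatter) in this assay and so provides the first measured step at this position. The change is modest, but it shows that this carbon is not indifferent to its substituent, with the chloro of compound 1 going with the stronger inhibition. Nothing available accounts for the step. The compounds shown leave open whether fluoro, bromo or methyl on the same carbon would match chloro or hydrogen, and whether a shorter or longer chain would alter the step.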